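Sulfonate series: urea nitrogen, propyl to cyclopropyl

The compounds below may be only part of what the source reports. "The series", "measured", "known", "first", "only" and "open" are said of these compounds alone.

Measured so far in a functional assay on MCF7 cells (Homo sapiens) for antiproliferative activity, read by sulforhodamine B assay, with a stated time of 48 h; a higher number here means a weaker inhibitor, a lower number a stronger inhibitor:
compound 1 `CC(=O)Nc1ccc(S(=O)(=O)Oc2ccccc2I)cc1` gives 27000 nM
compound 2 `CC(C)C(=O)Nc1ccc(S(=O)(=O)Oc2ccccc2I)cc1` gives 8100 nM
compound 3 `CCCNC(=O)Nc1ccc(S(=O)(=O)Oc2ccccc2I)cc1` gives 2900 nM

All three share the same core; they differ only in the group on the carbonyl carbon of the anilide. Compound 3 holds the lowest number of the three: the step of a 9.3-fold lower number from compound 1 to compound 3 (0.97 log units; beyond the scatter) and the step of a 2.8-fold lower number from compound 2 to compound 3 (0.45 log units; beyond the scatter) both lie beyond the scatter, as does the step of a 3.3-fold lower number from compound 1 to compound 2 (0.52 log units; beyond the scatter) between the other two. Compound 3 is therefore the reference point for the next change.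

Compound 4 `O=C(Nc1ccc(S(=O)(=O)Oc2ccccc2I)cc1)NC1CC1` keeps the urea and changes only the group on its outer nitrogen: cyclopropyl in place of propyl on an amide-type nitrogen. Going by the values given here, none of the measured steps touch this position; all three concern the carbonyl substituent itself, and the closest of them, the step from the isobutyryl to the propylurea, is modest. There is thus no measured precedent for exchanging the propyl for a three-carbon ring of the same heavy-atom count, and no reason from the data to expect a large shift in either direction in this assay.

The expected step is a 1.1-fold lower number from compound 3 to compound 4 (0.05 log units; within the scatter), small and within the scatter. Compound 4 is estimated at 2600 nM, with a range from 1000 nM to 7000 nM.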

Compound 4, half-maximal inhibitory concentration: 7400 nM
For compound 4 the middle estimate is 2.8-fold (0.45 log units) below the measured one; measured number above the stated range.
By their numbers in this assay, from the lowest: compound 3; then compounds 4 and 2 (each within the scatter of the next); then compound 1.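

In this assay, the outer nitrogen of the urea proves sensitive to the shape of its substituent: a 2.6-fold higher number from compound 3 to compound 4 (0.41 log units; beyond the scatter), although propyl and cyclopropyl both hold 3 heavy atoms and differ by the three-membered ring. The urea linkage alone therefore does not set the level reached by compound 3, since a 1.1-fold lower number from compound 2 to compound 4 (0.04 log units; within the scatter) leaves the cyclopropylurea level with the isopropyl amide, while a 3.6-fold lower number from compound 1 to compound 4 (0.56 log units; beyond the scatter) shows that it retains a modest gain over the methyl amide. No available evidence bears on what underlies the loss from propyl to cyclopropyl.

With only propyl and cyclopropyl shown on this nitrogen, it remains open whether the ring itself or the shorter reach of the substituent accounts for the step, a question that an isopropyl, a butyl or a cyclobutyl group at the same place could address. On these data alone, it also remains open whether a longer chain such as pentyl, or a chain ending in a hydroxyl or an amine, would give a lower number than compound 3.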